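The compounds below may be only part of what the source reports. "The series", "measured", "known", "first", "only" and "open" are said of these compounds alone.

Compound 1 `Cc1nc(N)sc1CCCN/C(N)=N/C(=O)N[C@@H](C)c1ccccc1` gives 1.08 in a functional assay on Right cardiac atrium for agonist activity at histamine H2 receptor (Cavia porcellus), with a stated time of 30 min, in the presence of a further agent that is not named here (on this read-out higher numbers stand for larger maximal responses and lower numbers for smaller maximal responses), the highest of the three numbers at hand. Compound 3 `Cc1nc(N)sc1CCCN/C(N)=N/C(=O)NC(C)c1ccc(F)cc1` gives 0.92 and compound 2 `Cc1nc(N)sc1CCCN/C(N)=N/C(=O)NC(c1ccccc1)c1ccccc1` gives 0.9; each of these lies beyond the scatter below compound 1, so compound 1 stands alone at the top.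

Compound 4 `CCCCCNC(=O)/N=C(\N)NCCCc1sc(N)nc1C` is still unmeasured. Against compound 1 it differs in one place: pentyl in place of 1-phenylethyl on an amide-type nitrogen. Among the compounds with values here, no measured pair carries this change, so the size of the step is not known. Since all three measured compounds reach close to the reference agonist's response, the author expects the step a number 0.13 lower from compound 1 to compound 4 (beyond the scatter) to be small, downward at most, or none beyond the scatter. Compound 4 is therefore estimated at 0.95, with a range from 0.8 to 1.1.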

Compound 4, intrinsic activity: the largest response reached, as a fraction of the reference agonist's: 0.78
The estimate for compound 4 lay 0.17 above the measured number; the measured number lies below the stated range.
By their numbers in this assay, from the lowest: compound 4; then compounds 2 and 3 (each within the scatter of the next); then compound 1.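

Pentyl in place of 1-phenylethyl on an amide-type nitrogen gives a number 0.30 lower from compound 1 to compound 4 (beyond the scatter) in this assay, the only step at this position that can be read. It shows that the maximal response depends on the group placed here, and that an open chain does not match the 1-phenylethyl of compound 1. Nothing at hand explains this step.

The change removes the aromatic ring and the stereocentre together, so their shares cannot be separated. From the compounds shown here alone, whether a 1-cyclohexylethyl group would hold the response of compound 1 remains open.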